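Swapping an aryl amide for an aminoalkyl amide

A few compounds are considered here, and "the series" means these few. Any claim that something is new, unique, unknown or untested is made for them only; others in the source may bear on it.

Measured so far:
compound 1, `O=C(CCC(=O)OCCCCCCSc1ccc([N+](=O)[O-])c2nonc12)Nc1ccccc1Cl`: 2950 nM
compound 2, `COc1ccccc1NC(=O)CCC(=O)OCCCCCCSc1ccc([N+](=O)[O-])c2nonc12`: 1610 nM
compound 3, `O=C(CCC(=O)OCCCCCCSc1ccc([N+](=O)[O-])c2nonc12)Nc1ccc(C(F)(F)F)cc1`: 1390 nM

In an ADME assay on HUVEC cells (Homo sapiens) for cytotoxicity, read by MTT assay, with a stated time of 72 h (a higher number here means a weaker inhibitor, a lower number a stronger inhibitor), compound 2 stands second highest of three numbers. The step of a 1.2-fold lower number from compound 2 to compound 3 (0.06 log units; within the scatter) is within the scatter, and so is a 1.8-fold lower number from compound 1 to compound 2 (0.26 log units; within the scatter); only a 2.1-fold lower number from compound 1 to compound 3 (0.33 log units; beyond the scatter) reaches beyond it, and modestly. Compound 4, `CN(C)CCCNC(=O)CCC(=O)OCCCCCCSc1ccc([N+](=O)[O-])c2nonc12`, is not yet measured. Its change from compound 2 is 3-(dimethylamino)propyl in place of 2-methoxyphenyl on an amide-type nitrogen. Among the measured compounds shown here, none of the measured steps covers this kind of change: each of them swaps one aromatic substituent for another on the same amide-type nitrogen, and all were small. The data therefore offer no direction, and the expected step of a 1.6-fold higher number from compound 2 to compound 4 (0.19 log units; within the scatter) is small. Compound 4 is estimated at 2500 nM, with a range from 700 nM to 9000 nM.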

Compound 4, half-maximal inhibitory concentration: 1600 nM
Compound 4: middle estimate off by 1.6-fold (0.19 log units), on the high side, within the range that was stated.
By their numbers in this assay, from the lowest: compounds 3, 4, 2 and 1 (each within the scatter of the next, the first and the last beyond it).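

In this assay the amide-type nitrogen takes an open chain as readily as an aromatic ring: 3-(dimethylamino)propyl in place of 2-methoxyphenyl gives no step beyond the scatter (a 1.0-fold lower number from compound 2 to compound 4 (0.00 log units; within the scatter)). The same holds against the other two aryl groups (a 1.2-fold higher number from compound 3 to compound 4 (0.06 log units; within the scatter); a 1.8-fold lower number from compound 1 to compound 4 (0.27 log units; within the scatter)), so among these compounds a ring on this nitrogen is not required for this level of cytotoxicity. Nothing shown explains why the number holds across this change.

On these data alone, it remains open whether a longer chain ending in a dimethylamino group, a plain alkyl chain without an amine, or a chain ending in a carboxylic acid would behave alike.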